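Working notes: amino in place of nitro on compound 2

The compounds below may be only part of what the source reports. "The series", "measured", "known", "first", "only" and "open" are said of these compounds alone.

compound 1 `COc1cc(C(=O)c2cn(-c3ccccc3)cc2-c2ccc(N)cc2)cc(OC)c1OC`: 9 nM
compound 2 `COc1cc(C(=O)c2cn(-c3ccc(F)cc3)cc2-c2ccc([N+](=O)[O-])cc2)cc(OC)c1OC`: 240 nM

Both values come from a functional assay on MCF7 cells (Homo sapiens) for cytotoxicity, read by MTT assay, with a stated time of 96 h; a lower number here means a stronger inhibitor, a higher number a weaker inhibitor. Compound 2 holds the higher of the two numbers at 240 nM, and the nearest value, from compound 1 at 9 nM, lies beyond the scatter.

The next compound is compound 3 `COc1cc(C(=O)c2cn(-c3ccc(F)cc3)cc2-c2ccc(N)cc2)cc(OC)c1OC`. It keeps the rest of compound 2 and carries amino in place of nitro on an aromatic carbon, para to a large group: amino in place of nitro on an aromatic carbon. The same difference reads 4-nitrophenyl to 4-aminophenyl.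

For the measured compounds named here, no measured pair isolates this change, so any expectation is indirect. Going by the values given here, the only measured compound with the 4-aminophenyl group is compound 1 at 9 nM, and this points to a lower number for compound 3 in this assay. Among the compounds with values here, with only two measured compounds, this is a weak basis. The estimated change, a drop expected to lie beyond the scatter, is a 16-fold lower number from compound 2 to compound 3 (1.20 log units; beyond the scatter). Compound 3 is expected at 15 nM, with an estimated range of 4 nM to 60 nM.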

Compound 3, half-maximal inhibitory concentration: 12 nM
Compound 3: middle estimate off by 1.3-fold (0.10 log units), on the high side; the range from low to high includes it.
By their numbers in this assay, from the lowest: compounds 1 and 3 (each within the scatter of the next); then compound 2.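

In this assay, amino in place of nitro on an aromatic carbon, para to a large group, now has a measured pair with the rest of the structure held constant: a 20-fold lower number from compound 2 to compound 3 (1.30 log units; beyond the scatter), a large step that rests on this single change. The second pair, a 1.3-fold higher number from compound 1 to compound 3 (0.12 log units; within the scatter), shows that fluoro in place of hydrogen on an aromatic carbon stays within the scatter when the 4-aminophenyl group is present, so the two changes that were combined between compound 1 and compound 2 can now be read largely apart, with the large step belonging to the nitro and amino exchange. Nothing at hand accounts for the size of this step.

The compounds shown leave open whether the fluoro change would also stay within the scatter with the 4-nitrophenyl group present, since that step has been read only with amino in place. From the compounds shown here alone, only nitro and amino are seen at this position, so it remains open whether a hydroxyl, a methylamino or an acetamido group there would give values nearer compound 3 or compound 2.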